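Hydroxyl for Butyl: Expected Solubility of Compound 4

The source may hold more compounds than are shown below. What is called first, only, known or untested is meant among the compounds shown, and "the series" means these compounds.

Compound 1 `CCCCc1nc2c(C#N)c(C)c(-c3ccccc3)c(N3CC[C@H](N(C)C)C3)n2n1` — 33 ug/mL
Compound 2 `Cc1c(-c2ccccc2)c(N2CC[C@H](N(C)C)C2)n2nc(C(C)(C)C)cc2c1C#N` — < 2 ug/mL
Compound 3 `Cc1c(C(C)(C)C)c(N2CC[C@H](N(C)C)C2)n2nc(C(C)(C)C)nc2c1C#N` — 146 ug/mL

Three compounds have been run in a physicochemical assay for solubility, at pH 6.8; a lower number here means a less soluble compound, a higher number a more soluble compound. Compound 1 gives 33 ug/mL, the lower of the two numbers reported. Compound 3 gives 146 ug/mL, a step above compound 1 that lies beyond the scatter. For compound 2 the assay reports only a limit, < 2 ug/mL, and not a number (the limit of < 2 ug/mL in this assay, at which 1 of the 3 values shown sits).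

Compound 4 `Cc1c(-c2ccccc2)c(N2CC[C@H](N(C)C)C2)n2nc(C(C)(C)CO)nc2c1C#N` has not been measured. It differs from compound 1 in one place: 1-(hydroxymethyl)-1-methylethyl in place of butyl on an aromatic carbon. Within the data shown here, no single-point step between measured compounds is available, so the size of this change must be estimated. A modest rise in this assay is expected, a 2.4-fold higher number from compound 1 to compound 4 (0.38 log units; beyond the scatter). Compound 4 is accordingly estimated at 80 ug/mL, within a range from 30 ug/mL to 220 ug/mL.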

Compound 4, solubility: 140 ug/mL
Beside the measured number, compound 4's estimate is 1.8-fold (0.24 log units) below it, and the stated range covers the measured number.
By their numbers in this assay, from the lowest: compound 1; then compounds 4 and 3 (each within the scatter of the next). At a limit, below all of these: compound 2.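

In this assay, the aromatic carbon between two ring nitrogen atoms now has a step that can be read on its own: 1-(hydroxymethyl)-1-methylethyl in place of butyl gives a 4.2-fold higher number from compound 1 to compound 4 (0.63 log units; beyond the scatter) on the otherwise unchanged core of compound 1. The earlier compounds shown here differ from one another in more than one place, so they could not isolate any change at this position. Open, on these data alone, is whether this step follows the hydroxyl or the branched chain, and how a carboxylic acid or an amine would read at this position. Nothing measured among the compounds shown gives a cause for the step.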